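The source may hold more compounds than are shown below. What is called first, only, known or untested is meant among the compounds shown, and "the series" means these compounds.

Compound 1 `COc1ccc(C2CC(Nc3nc4ccc(Cl)cc4s3)=NN2C(C)=O)cc1`: 93.3 umol/kg
Compound 2 `CC(=O)N1N=C(Nc2nc3ccc(Cl)cc3s2)CC1c1ccccc1`: 161 umol/kg
Compound 3 `CC(=O)N1N=C(Nc2nc3ccc([N+](=O)[O-])cc3s2)CC1c1ccc(Cl)cc1`: 132 umol/kg

In a functional assay on the whole organism (Hindlimb, strain albino) with Mus musculus as the target, in the maximal electroshock model, with a stated time of 0.5 h (on this read-out higher numbers stand for an effect only at larger amounts of compound and lower numbers for an effect already at smaller amounts), compound 3 stands second highest of these three numbers; its nearest neighbour is compound 2 and its furthest is compound 1, and both gaps lie within the scatter. Compound 4 `CC(=O)N1N=C(Nc2nc3ccc(Cl)cc3s2)CC1c1ccc(Cl)cc1` differs from compound 3 by chloro in place of nitro on an aromatic carbon. Within the data shown here, no measured step exchanges a nitro for a chloro on this ring. Among the measured compounds shown here, the only measured step, a 1.7-fold higher number from compound 1 to compound 2 (0.24 log units; within the scatter), concerns a different ring and stays within the scatter. There is therefore no basis for expecting a step beyond the scatter here, so the expected step is a 1.1-fold lower number from compound 3 to compound 4 (0.04 log units; within the scatter). Compound 4 is estimated at 120 umol/kg, in a range from 60 umol/kg to 240 umol/kg.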

Compound 4, dose for half-maximal effect: 79.5 umol/kg
Compound 4: middle estimate off by 1.5-fold (0.18 log units), on the high side; low and high end bracket the measured number.
By their numbers in this assay, from the lowest: compounds 4, 1, 3 and 2 (each within the scatter of the next, the first and the last beyond it).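

On the aromatic ring that is part of the fused system, chloro and nitro cannot be told apart (a 1.7-fold lower number from compound 3 to compound 4 (0.22 log units; within the scatter)). On the other aromatic ring, chloro in place of hydrogen gives a modest gain that passes the scatter (a 2.0-fold lower number from compound 2 to compound 4 (0.31 log units; beyond the scatter)), whereas chloro and methoxy there cannot be told apart (a 1.2-fold lower number from compound 1 to compound 4 (0.07 log units; within the scatter)). No measurement available here explains these results. As far as these compounds go, what an amine or a carboxylic acid would do at either place remains open. So does the effect of hydrogen on the fused ring.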